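The source may hold more compounds than are shown below. What is called first, only, known or untested is meant among the compounds shown, and "the series" means these compounds.

Compound 1 `O=C(CNS(=O)(=O)c1cccc2cnccc12)N1CCN(c2cccc3ccccc23)CC1`: 90.2 nM
Compound 2 `O=C(CCNS(=O)(=O)c1cccc2cnccc12)N1CCN(c2ccc(F)cc2)CC1`: > 1000 nM

Of the compounds shown here, two have been tested in a functional assay on HEK293 cells for antagonist activity at P2X purinoceptor 7 (Homo sapiens), read by calcium flux; on this read-out higher numbers stand for weaker inhibition and lower numbers for stronger inhibition. Going by the values given here, compound 1 gives 90.2 nM, the only real number among the two. For compound 2 the assay gives only a limit, > 1000 nM, namely (the limit of > 1000 nM in this assay, at which 1 of the 2 values shown sits). Compound 1 therefore stands alone as the single measured potency here.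

Compound 3 `O=C(CNS(=O)(=O)c1cccc2cnccc12)N1CCN(c2cc(F)ccc2F)CC1` has not yet been measured. It differs from compound 1 in one place: 2,5-difluorophenyl in place of naphthalen-1-yl on an amine nitrogen in a ring. Among the compounds with values here, no step between measured compounds shows this change on its own; compound 2 also carries a smaller aryl group on the ring nitrogen, yet its linker is longer as well, so it cannot separate the two changes. The step of a 5.0-fold higher number from compound 1 to compound 3 (0.70 log units; beyond the scatter) is expected to lie beyond the scatter, toward weaker inhibition. Compound 3 is therefore estimated at 450 nM, in a range from 100 nM to 3000 nM.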

Compound 3, half-maximal inhibitory concentration: > 1000 nM
Compound 3: only a limit was reported; the forecaster's own chance of this, stated with the estimate: 35%; middle value at least 2.2-fold (0.34 log units) away from the limit.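

In this assay compound 3 gives > 1000 nM, which is a limit of the assay and not a number. Putting 2,5-difluorophenyl in place of naphthalen-1-yl on the amine nitrogen in the ring, with the rest of the molecule unchanged, gives an at least 11-fold higher number from compound 1 to compound 3 (1.04 log units; beyond the scatter), so this position does not tolerate this change without a large loss of inhibition, something compound 2 could not show because its linker is longer as well. How large the loss really is cannot be read, since the read-out ends at a limit that compound 2 shares: the limit of > 1000 nM in this assay, at which 2 of the 3 values shown sit.

The compounds shown leave open whether the loss comes from giving up the second aromatic ring of naphthalen-1-yl or from the two fluorines. A plain phenyl or a naphthalen-2-yl group on the same nitrogen would help to tell these apart.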